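This account rests on a few compounds, and the source may have more. Where it says the series, first, only, none or still open, it means among the compounds named here.

Measured so far:
- compound 1 `C=CC(=O)Nc1cccc(Oc2nc(Nc3ccc(OC)cc3)nc3c2CSCC3)c1`: 4220 nM
- compound 2 `CCC/C=C/C(=O)Nc1cccc(Oc2nc(Nc3ccc(OC)cc3)nc3c2CSCC3)c1`: 11900 nM
- compound 3 `COc1ccc(Nc2nc3c(c(Oc4cccc(NC(=O)C=C(C)C)c4)n2)CSCC3)cc1`: 26900 nM

In a functional assay on A549 cells (Homo sapiens) for antiproliferative activity, read by MTT assay, with a stated time of 72 h (on this read-out higher numbers stand for weaker inhibition and lower numbers for stronger inhibition), compound 3 gives 26900 nM, the highest number of the three and so the weakest inhibition in this set. The nearest value lies a 2.3-fold higher number from compound 2 to compound 3 (0.35 log units; beyond the scatter), and the furthest lies a 6.4-fold higher number from compound 1 to compound 3 (0.80 log units; beyond the scatter).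

The next compound, compound 4 `COc1ccc(Nc2nc3c(c(Oc4cccc(NC(=O)/C=C/C(C)C)c4)n2)CSCC3)cc1`, is still unmeasured. It carries 3-methylbut-1-en-1-yl in place of 2-methylprop-1-en-1-yl on a carbonyl carbon.

Of the measured groups, pent-1-en-1-yl in compound 2 looks closest to the entering group, so the most relevant comparison is a 2.3-fold higher number from compound 2 to compound 3 (0.35 log units; beyond the scatter). The other relevant step is a 2.8-fold higher number from compound 1 to compound 2 (0.45 log units; beyond the scatter), which shows that this group still gives a higher number than vinyl. Compound 4 is therefore expected to fall near compound 2 at 11900 nM, with a modest move towards a lower number in this assay. The expected step is a 2.2-fold lower number from compound 3 to compound 4 (0.35 log units; beyond the scatter). For compound 4 the estimated value is 12000 nM, with an expected range of 5000 nM to 28000 nM.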

Compound 4, half-maximal inhibitory concentration: 25900 nM
The estimate for compound 4 lay 2.2-fold (0.33 log units) below the measured number, and the stated range covers the measured number.
By their numbers in this assay, from the lowest: compound 1; then compound 2; then compounds 4 and 3 (each within the scatter of the next).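

In this assay, 3-methylbut-1-en-1-yl in place of 2-methylprop-1-en-1-yl on a carbonyl carbon gives a 1.0-fold lower number from compound 3 to compound 4 (0.02 log units; within the scatter), so moving the branch along the chain separates these two compounds by no more than the scatter, while isopropyl in place of propyl gives a 2.2-fold higher number from compound 2 to compound 4 (0.34 log units; beyond the scatter) and so shows that the branched chain end, not only substitution of the vinyl group, matters at this position. Against the unsubstituted group the new compound gives a 6.1-fold higher number from compound 1 to compound 4 (0.79 log units; beyond the scatter), which places both branched groups on the same side of compound 2, with vinyl giving the lowest number of the series. No measurement at hand bears on why these steps arise.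

Still open, from the compounds shown here alone, is whether an amine on the chain, such as dimethylaminomethyl in place of the isopropyl end, would bring the number back towards that of compound 1. Also open, going by these compounds, is whether ethyl on the carbonyl carbon, which lacks the double bond, would match vinyl.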